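The compounds below may be only part of what the source reports. "The series", "measured", "known", "first", "only" and "open" are said of these compounds alone.

Compound 1 `COc1ccc2c(=O)cc(/C=C/c3ccc(OC(F)(F)F)cc3)oc2c1`: > 40000 nM; compound 2 `COc1cc(OC)c2c(=O)cc(/C=C/c3ccccc3)oc2c1`: 21500 nM; compound 3 `COc1ccc(/C=C/c2cc(=O)c3c(OC)cc(OC)cc3o2)cc1`: > 40000 nM.

In a functional assay on A549 cells (Homo sapiens) for antiproliferative activity, read by MTT assay, with a stated time of 12 h (on this read-out lower numbers stand for stronger inhibition and higher numbers for weaker inhibition), compound 2 gives 21500 nM. Compound 1 reaches only a limit of the assay, > 40000 nM. Compound 3 likewise reports only a limit, > 40000 nM. How the cores of compound 1 and compound 2 differ is not broken down here. Compound 3 differs from compound 2 by methoxy in place of hydrogen on an aromatic carbon, and the assay shows an at least 1.8-fold higher number from compound 2 to compound 3 (0.26 log units; that floor lies within the scatter). Compound 4 `COc1ccc2c(=O)cc(/C=C/c3ccc(OC(F)(F)F)cc3)oc2c1OC` differs from compound 1 by methoxy in place of hydrogen on an aromatic carbon. The places are not the same: in compound 3 the methoxy enters para to a large group, whereas in compound 4 it enters on a ring that is part of a fused or bridged system of two rings, ortho to a fused ring, ortho to a methoxy group and meta to a fused ring, so this is the same kind of change rather than the same change. The measured step went toward a higher number, and compound 1 already sits at the limit of > 40000 nM in this assay, at which 2 of the 3 values shown sit. Compound 4 is therefore expected to remain at or beyond that limit, with an estimated step that the limit leaves unreadable from compound 1 to compound 4. Compound 4 is estimated at 60000 nM, expected between 20000 nM and 200000 nM.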

Compound 4, half-maximal inhibitory concentration: > 40000 nM
Compound 4 was reported as a limit; the forecaster's own chance of this, stated with the estimate: 85%; the middle value lies beyond the limit too.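

In this assay compound 4 reports only a limit, > 40000 nM. Among these compounds, compound 1 stands at a limit as well, so no step from compound 1 to compound 4 can be read. The compounds shown leave open what methoxy in place of hydrogen does on the core of compound 1, and how weak compound 1, compound 3 and compound 4 truly are.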